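The source may hold more compounds than are shown below. What is called first, only, known or untested is meant among the compounds shown, and "the series" means these compounds.

Working notes on the series.

In a functional assay on CHO cells for antagonist activity at Orexin/Hypocretin receptor type 1 (Homo sapiens), read by FLIPR and calcium flux (on this read-out lower numbers stand for lower potency and higher numbers for higher potency (the scale is a negative logarithm)), compound 1 `O=C(c1cc(Cl)ccc1-c1ncccn1)N1CC2(CC2)C[C@H]1CNc1cc(C(F)(F)F)ccn1` gives 8.1, compound 2 `Cc1nc(C(=O)N2CC3(CC3)C[C@H]2CNc2cc(C(F)(F)F)ccn2)c(-c2ccccc2)s1` gives 8.2, and compound 3 `Cc1ccc(-c2ncccn2)c(C(=O)N2CC3(CC3)C[C@H]2CNc2cc(C(F)(F)F)ccn2)c1` gives 7.3. Among the compounds with values here, compound 3 stands lowest of the three numbers measured so far; its nearest neighbour is compound 1 and its furthest is compound 2, both beyond the scatter. Within the data shown here, the only step between measured compounds that differ in one place is a number 0.80 log units lower from compound 1 to compound 3 (beyond the scatter), and it concerns the aryl ring of the amide, not the pyridine carried on the amine nitrogen.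

Compound 4 `Cc1ccc(-c2ncccn2)c(C(=O)N2CC3(CC3)C[C@H]2CNc2ccc(C(F)(F)F)cn2)c1` differs from compound 3 by 5-(trifluoromethyl)pyridin-2-yl in place of 4-(trifluoromethyl)pyridin-2-yl on an amine nitrogen. No measured step in this assay touches the pyridine, so the change has no direct precedent here, and the expected size of the step in this assay cannot be read from the numbers shown. In the absence of such a step, a modest downward movement in this assay is expected for compound 4, a number 0.30 log units lower from compound 3 to compound 4 (within the scatter), with a wide range. Compound 4 is therefore estimated at 7, between 6.2 and 7.8.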

Compound 4, negative logarithm of the antagonist equilibrium constant: 8.7
Beside the measured number, compound 4's estimate is 1.70 log units below it; the whole stated range lies below it.
By their numbers in this assay, from the lowest: compound 3; then compounds 1 and 2 (each within the scatter of the next); then compound 4.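

The position on the amine nitrogen is highly sensitive in this assay: exchanging 4-(trifluoromethyl)pyridin-2-yl for 5-(trifluoromethyl)pyridin-2-yl gives a number 1.40 log units higher from compound 3 to compound 4 (beyond the scatter), although the two groups have the same atoms and the same counts. Within the data shown here, this is the first measured step at the pyridine, and it is large, whereas the one earlier step, at the aryl ring of the amide, is a number 0.80 log units lower from compound 1 to compound 3 (beyond the scatter) and modest. No measurement on hand accounts for the difference between these two isomeric groups.

Going by these compounds, whether 5-(trifluoromethyl)pyridin-2-yl brings a step of similar size with the amide portions of compound 1 and compound 2 remains open. Also open, on these data alone, is what a nitrile or a methoxy group would give in place of trifluoromethyl on the pyridine.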